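The source may hold more compounds than are shown below. What is called first, only, known or untested is meant among the compounds shown, and "the series" means these compounds.

- compound 1 `O=C(NCc1cc(Cl)ccc1-n1cnnn1)[C@@H]1C[C@@H]2C[C@@H]2N1C(=O)[C@H](O)CC1CC1`: 1700 nM
- compound 2 `O=C(NCc1cc(Cl)ccc1-n1cnnn1)[C@@H]1C[C@@H]2C[C@@H]2N1C(=O)[C@H](O)c1cccc(Cl)c1`: 1000 nM

In a functional assay on a cell-free system (plasma, Homo sapiens), with a stated time of 3 min (a higher number here means a weaker inhibitor, a lower number a stronger inhibitor), compound 1 gives 1700 nM and compound 2 gives 1000 nM. These two numbers sit within the scatter of each other, so compound 1 has no clear rank. Compound 3 `O=C(NCc1cc(Cl)ccc1-n1cnnn1)[C@@H]1C[C@H]2C[C@H]2N1C(=O)[C@H](O)CC1CC1` has the same atoms and bonds as compound 1 and differs only in configuration as drawn (the two compounds have the same atoms and bonds and differ only in configuration as drawn: 2 of 4 stereo elements differ; a stereocentre at a saturated ring carbon is drawn S in compound 1 and R in compound 3; a stereocentre at a saturated ring carbon is drawn S in compound 1 and R in compound 3): two stereocentres at saturated ring carbons are drawn S in compound 1 and R in compound 3.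

For the measured compounds named here, the only measured step is a 1.7-fold lower number from compound 1 to compound 2 (0.23 log units; within the scatter). It puts 3-chlorophenyl in place of cyclopropylmethyl and leaves those ring carbons unchanged, so it gives no guide to this change. Going by the values given here, no measured pair tests configuration, which leaves the direction open and the range wide. In this assay, the expected step is a 1.5-fold higher number from compound 1 to compound 3 (0.17 log units; within the scatter), with no shift beyond the scatter as the central expectation. Compound 3 is estimated at 2500 nM, with an expected range of 600 nM to 10000 nM.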

Compound 3, half-maximal inhibitory concentration: 850 nM
Beside the measured number, compound 3's estimate is 2.9-fold (0.47 log units) above it; the range from low to high includes it.
By their numbers in this assay, from the lowest: compounds 3, 2 and 1 (each within the scatter of the next).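

Compound 1 and compound 2 differ in a side group, so they said nothing about the two saturated ring carbons; this new pair tests those carbons directly. In this assay, redrawing both stereocentres from S to R gives a 2.0-fold lower number from compound 1 to compound 3 (0.30 log units; within the scatter), so this change does not clearly separate the two configurations in this assay. The comparison is a clean one, with configuration the only variable in play: the fact that compounds 1 and 3 differ only in the configuration as drawn

From the compounds shown here alone, both stereocentres change together here, so the contribution of each alone remains unknown, as does whether the same change would read alike with the 3-chlorophenyl group of compound 2 in place of cyclopropylmethyl. Also open, going by these compounds, is how this assay would respond to a different group on the chain carbon, such as an amine in place of the hydroxyl.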